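Selenium Gives Way to Sulfur on the Shared Core

The compounds below may be only part of what the source reports. "The series", "measured", "known", "first", "only" and "open" are said of these compounds alone.

Measured compounds:
compound 1, `OCC#CCSc1cnc2ccccc2c1SCC#CCO`: 32 ug/mL
compound 2, `C#CCSc1cnc2ccccc2c1[Se]CC#CCBr`: 2.2 ug/mL
compound 3, `C#CCSc1cnc2ccccc2c1[Se]CC#CCO`: 3.3 ug/mL

In a functional assay on SW707 cells (Homo sapiens) for cytotoxicity, read by sulforhodamine B assay, with a stated time of 72 h (a lower number here means a stronger inhibitor, a higher number a weaker inhibitor), compound 3 gives 3.3 ug/mL, the second highest of the three numbers. Its nearest neighbour is compound 2, and the step of a 1.5-fold higher number from compound 2 to compound 3 (0.18 log units; within the scatter) lies within the scatter, so the two cannot be ordered. Its furthest neighbour is compound 1, which gives 32 ug/mL in this assay, a gap that does exceed the scatter.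

Compound 4, `C#CCSc1cnc2ccccc2c1SCC#CCO`, is the next case. It differs from compound 3 in one place: a group of 6 heavy atoms (4 carbon, 1 oxygen, 1 sulfur; no ring) in place of a group of 6 heavy atoms (4 carbon, 1 oxygen, 1 selenium; no ring), on an aromatic carbon. Within the data shown here, no measured step touches this position. Among the measured compounds shown here, the only step known, a 1.5-fold higher number from compound 2 to compound 3 (0.18 log units; within the scatter), concerns the far end of the chain on the other side of the core and is within the scatter, so it says nothing about the selenium-to-sulfur exchange. Compound 1 does carry sulfur at this position, but it also carries a different chain on the other sulfur, so its value of 32 ug/mL against the value of compound 3 mixes two changes.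

With direct evidence lacking, the expected step of a 2.4-fold higher number from compound 3 to compound 4 (0.38 log units; beyond the scatter) is a modest rise toward a weaker number, kept within a wide range. Compound 4 is therefore estimated at 8 ug/mL, between 3 ug/mL and 25 ug/mL.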

Compound 4, concentration for 50% inhibition: 42.6 ug/mL
For compound 4 the middle estimate is 5.3-fold (0.73 log units) below the measured one, and the stated range ends below it.
By their numbers in this assay, from the lowest: compounds 2 and 3 (each within the scatter of the next); then compounds 1 and 4 (each within the scatter of the next).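

In this assay, among these compounds, the exchange of the selenium-bearing chain for its sulfur counterpart on the aromatic carbon opposite the ring nitrogen gives the first direct reading at this position, and it is a large one: a 13-fold higher number from compound 3 to compound 4 (1.11 log units; beyond the scatter). The comparison with the bromo-ended selenium chain points the same way, a 19-fold higher number from compound 2 to compound 4 (1.29 log units; beyond the scatter), although that step also replaces bromo with hydroxy at the end of the chain. With sulfur at this position, hydrogen in place of hydroxymethyl on a triple-bonded carbon gives a 1.3-fold higher number from compound 1 to compound 4 (0.12 log units; within the scatter), which lies within the scatter, so among these four compounds the two that carry selenium have the lower numbers and neither compound with sulfur there goes against this.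

Nothing available here explains why the selenium and sulfur compounds stand so far apart. On these data alone, it remains open whether the selenium compounds would keep their lower numbers with an amine or a carboxylic acid in place of the hydroxy at the chain end, or with a longer chain at this position.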